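The source may hold more compounds than are shown below. What is called first, only, known or untested is meant among the compounds shown, and "the series" means these compounds.

Compound 1 `COc1cc(-c2nccn2C)cc(OC)c1OC`: > 100000 nM (a limit)
Compound 2 `COc1cc(-c2nccn2C(C)C)cc(OC)c1OC`: > 100000 nM (a limit)
Compound 3 `CCCCn1ccnc1-c1cc(OC)c(OC)c(OC)c1`: > 100000 nM (a limit)

In a functional assay on HT-29 cells (Homo sapiens) for antiproliferative activity, read by MTT assay, with a stated time of 72 h (on this read-out higher numbers stand for weaker inhibition and lower numbers for stronger inhibition), compound 3 stands at > 100000 nM, which is a limit and not a number. Compounds 1 and 2 share that position, as the limit of > 100000 nM in this assay, at which 3 of the 3 values shown sit, records. Compound 4 `COc1cc(-c2nccn2-c2ccc(C)cc2)cc(OC)c1OC` carries 4-methylphenyl in place of butyl on an aromatic nitrogen. For the measured compounds named here, three measured steps bear on this change: a step that the two limits leave unreadable from compound 1 to compound 2, a step that the two limits leave unreadable from compound 1 to compound 3 and a step that the two limits leave unreadable from compound 2 to compound 3. None gives a size to carry over, and none of these compounds has a ring on that nitrogen. The expected change is an at least 12-fold lower number from compound 3 to compound 4 (1.09 log units; beyond the scatter), towards stronger inhibition in this assay, though this is only a cautious expectation. For compound 4 the estimated value is 8000 nM, with an expected range from 300 nM to 100000 nM.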

Compound 4, half-maximal inhibitory concentration: 1600 nM
Estimate against measurement, compound 4: 5.0-fold (0.70 log units) above; low and high end bracket the measured number.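

In this assay the change to 4-methylphenyl gives an at least 62-fold lower number from compound 3 to compound 4 (1.79 log units; beyond the scatter) and an at least 62-fold lower number from compound 2 to compound 4 (1.79 log units; beyond the scatter) and an at least 62-fold lower number from compound 1 to compound 4 (1.79 log units; beyond the scatter) as well, so the group on this aromatic nitrogen can decide whether any activity is read at all. The steps among compounds 1, 2 and 3 cannot be read, and all three stay at a limit: the limit of > 100000 nM in this assay, at which 3 of the 4 values shown sit. Compound 4 is the only one shown with a ring on that nitrogen, so this is the first readable change here. As far as these compounds go, whether the ring alone is enough stays open, and plain phenyl or benzyl would test that. From the compounds shown here alone, the effect of an amine on that ring also remains unknown.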